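Vinyl for Methyl on the Chain at the Ring Nitrogen

The source may hold more compounds than are shown below. What is called first, only, known or untested is meant among the compounds shown, and "the series" means these compounds.

Measured so far:
compound 1, `C=CCn1c(SCC(=O)Nc2ccc(C(C)=O)cc2)nnc1-c1ccc(OC)c(OC)c1`, gives 64%;
compound 2, `CCn1c(SCC(=O)Nc2ccc(C(C)=O)cc2)nnc1-c1ccc(OC)cc1`, gives 62%.

Of the compounds shown here, two have been tested in a functional assay on the whole organism (strain albino) for inhibition, with Rattus norvegicus as the target, read by paw edema, with stated times of 30 min and 5 h, at a dose of 0.28 mmol/kg by the oral route (a higher number here means more inhibition at the dose given (going by the name of the read-out), a lower number less inhibition), and their two numbers tell the same story. Compound 2 holds the lower of the two values, but compound 1 stands only a small distance above it, a gap that lies within the scatter, so no order between them can be claimed.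

Compound 3, `C=CCn1c(SCC(=O)Nc2ccc(C(C)=O)cc2)nnc1-c1ccc(OC)cc1`, has not yet been measured in this assay. It differs from compound 2 in one place: vinyl in place of methyl on a saturated chain carbon bound to an aromatic nitrogen. Cut one bond further out, the same change reads ethyl to allyl.

Among the measured compounds shown here, no step between two measured compounds that differ in a single place is available, so the size of this step has no precedent here. Given that both measured compounds sit close together in this assay, the step from compound 2 to compound 3 is expected to be small, a number 1 percentage points higher from compound 2 to compound 3 (within the scatter), with no direction beyond the scatter. Compound 3 is therefore estimated at 63%, within the range 52% to 74%.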

Compound 3, a percentage reported as inhibition, in the whole organism at one dose (the size of the read-out at that dose, not a potency): 66%
Estimate against measurement, compound 3: 3 percentage points below, and the stated range covers the measured number.
By their numbers in this assay, from the lowest: compounds 2, 1 and 3 (each within the scatter of the next).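

In this assay, vinyl in place of methyl on a saturated chain carbon bound to an aromatic nitrogen gives a number 4 percentage points higher from compound 2 to compound 3 (within the scatter), the first single-place step read at this position, and it shows that the ethyl and allyl chains cannot be told apart in this test at this one dose. Hydrogen in place of methoxy on an aromatic carbon gives a number 2 percentage points higher from compound 1 to compound 3 (within the scatter), so this second single-place step also stays inside the scatter and the read-out separates neither pair of compounds. No measurement is available that bears on why these two steps are as small as they are.

The compounds shown leave open whether a larger change on the saturated chain carbon bound to the aromatic nitrogen, such as a propyl chain, a benzyl group or a chain ending in an amine or a carboxylic acid, would carry the number beyond the scatter. They also leave open whether a group such as chlorine or hydroxyl in place of methoxy on the aromatic carbon would do so, and whether the steps seen here would hold at another dose.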